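The compounds below may be only part of what the source reports. "The series", "measured", "known", "first", "only" and "open" are said of these compounds alone.

Among the measured compounds shown here, in an ADME assay on microsomes from liver (Homo sapiens) for metabolic stability, tested at 2.5 uM (on this read-out higher numbers stand for fast clearance and lower numbers for slow clearance), compound 2 `Cc1ccc(S(=O)(=O)c2cnc3cc(F)ccc3c2-c2cccc(F)c2)cc1F` gives 0.41 mL/min, the lower of the two numbers measured so far; compound 1 `COc1ccc(S(=O)(=O)c2cnc3cc(F)ccc3c2-c2cccc(Cl)c2)cc1Cl` gives 1.19 mL/min, a gap beyond the usual scatter, although these two compounds differ in more than one place. Compound 3 `Cc1ccc(S(=O)(=O)c2cnc3cc(F)ccc3c2-c2cccc(Cl)c2)cc1F` has not yet been tested. It differs from compound 2 by a single change: chloro in place of fluoro on an aromatic carbon. For the measured compounds named here, no measured pair isolates this change, so the expectation rests on the two values alone. The step of a 1.3-fold higher number from compound 2 to compound 3 (0.13 log units; within the scatter) is expected to be a modest rise in clearance, close to the edge of the scatter. Compound 3 is therefore estimated at 0.55 mL/min, in a range from 0.3 mL/min to 1 mL/min.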

Compound 3, intrinsic clearance in a liver preparation (reported as CLH), per the amount of preparation that the assay uses: 2.13 mL/min
Beside the measured number, compound 3's estimate is 3.9-fold (0.59 log units) below it; the measured number lies above the stated range.
By their numbers in this assay, from the lowest: compound 2; then compounds 1 and 3 (each within the scatter of the next).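

In this assay, among the compounds shown here, the exchange of 3-fluorophenyl for 3-chlorophenyl, read alone for the first time, gives a 5.2-fold higher number from compound 2 to compound 3 (0.72 log units; beyond the scatter), so this single halogen swap on an aromatic carbon is enough to move clearance beyond the scatter. The change on the sulfonyl sulfur, 3-chloro-4-methoxyphenyl to 3-fluoro-4-methylphenyl, read in the direction listed, gives a 1.8-fold higher number from compound 1 to compound 3 (0.25 log units; within the scatter), which stays within the scatter. Nothing available explains either result.

On these data alone, whether a nitrile or a trifluoromethyl group on that aromatic carbon would sit nearer compound 2 or compound 3 remains open.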